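The compounds below may be only part of what the source reports. "The series", "measured", "known", "first", "only" and "open" are said of these compounds alone.

Going by the values given here, in an assay on CHO cells for displacement of a labelled ligand from 5-hydroxytryptamine receptor 7 (Homo sapiens) (on this read-out lower numbers stand for stronger inhibition and higher numbers for weaker inhibition), compound 2 `COc1ccc(S(=O)(=O)NCCCN2CCN(c3ccc(C(F)(F)F)cc3)CC2)cc1` gives 384 nM, which is the highest of the two numbers measured so far. The nearest is compound 1 `COc1ccc(S(=O)(=O)NCCCN2CCN(c3cccc(C(F)(F)F)c3)CC2)cc1`, which in this assay gives 89 nM, so that the step of a 4.3-fold higher number from compound 1 to compound 2 (0.63 log units; beyond the scatter) follows from moving the trifluoromethyl group on the aryl attached to the amine nitrogen in the ring. Compound 3 `COc1ccc(S(=O)(=O)NCCCN2CCN(c3ccc(C(C)=O)cc3)CC2)cc1` in this assay gives only > 10000 nM, and this is a limit of the assay rather than a number (the limit of > 10000 nM in this assay, at which 1 of the 3 values shown sits). Both an at least 110-fold higher number from compound 1 to compound 3 (2.05 log units; beyond the scatter) and an at least 26-fold higher number from compound 2 to compound 3 (1.41 log units; beyond the scatter) are large steps. Both of these changes sit on the aryl attached to the amine nitrogen in the ring.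

Compound 4 `O=S(=O)(NCCCN1CCN(c2ccc(C(F)(F)F)cc2)CC1)c1ccc2ccccc2c1` differs from compound 2 elsewhere: naphthalen-2-yl in place of 4-methoxyphenyl on a sulfonyl sulfur. Among the compounds with values here, none of the three measured steps touches the group on the sulfonyl sulfur, so no measured step bears directly on this change, and the data give no direction for it. Compound 4 is therefore expected to stay close to compound 2, with a step of a 1.3-fold lower number from compound 2 to compound 4 (0.11 log units; within the scatter) that may not exceed the scatter. The estimate for compound 4 in this assay is 300 nM, with a range from 80 nM to 1200 nM.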

Compound 4, half-maximal inhibitory concentration: 567 nM
Compound 4: middle estimate off by 1.9-fold (0.28 log units), on the low side; the measured number falls inside the stated range.
By their numbers in this assay, from the lowest: compound 1; then compounds 2 and 4 (each within the scatter of the next). At a limit, above all of these: compound 3.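

In this assay, going by these compounds alone, the step of a 1.5-fold higher number from compound 2 to compound 4 (0.17 log units; within the scatter) is the first measured change on the sulfonyl sulfur, and it shows that naphthalen-2-yl can stand in place of 4-methoxyphenyl there without a difference that clears the scatter. The exchange gives up the hydrogen-bond acceptor of the 4-methoxyphenyl group and brings in a second six-membered aromatic ring of carbon only, yet the two compounds cannot be told apart on this read-out, whereas a change on the aryl attached to the amine nitrogen, a 4.3-fold higher number from compound 1 to compound 2 (0.63 log units; beyond the scatter), does clear the scatter. The only limit among the values concerns a different change, so nothing shown accounts for how little this exchange moves the number.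

Going by these compounds, it remains open whether this insensitivity extends beyond these two aromatic groups, for instance to a small methyl group, or to a carboxylic acid or an amine on the aromatic ring at the sulfonyl sulfur. On these data alone, it is equally open whether naphthalen-2-yl behaves the same way alongside the 3-(trifluoromethyl)phenyl group of compound 1, or with a longer chain in the core.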